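This account rests on a few compounds, and the source may have more. Where it says the series, first, only, none or still open, it means among the compounds named here.

Of the compounds shown here, three of a shared core have been tested in a functional assay on the whole organism with Scenedesmus acutus as the target, with a stated time of 20 h; a higher number here means a weaker inhibitor, a lower number a stronger inhibitor. Compound 1, `S=c1n(-c2ccc(OCc3ccc(Cl)cc3)cc2)c(=S)n2n1CCCC2`, gives 22.9 nM. Compound 2, `COC(=O)CSc1cc(/N=c2\sc(=S)n3n2CCCC3)c(F)cc1Cl`, gives 389 nM. Compound 3, `S=c1n(-c2ccccc2)c(=S)n2n1CCCC2`, gives 2040 nM. Among these three numbers compound 2 stands second highest: the nearest is compound 3, whose number is higher by more than the usual scatter, and the furthest is compound 1, whose number is lower by well more than the scatter. So compound 2 sits between a clearly stronger and a clearly weaker inhibitor.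

Compound 4, `C#CCOc1cc(/N=c2\sc(=S)n3n2CCCC3)c(F)cc1Cl`, has not yet been measured in this assay. It differs from compound 2 in one place: propargyloxy in place of ((methoxycarbonyl)methyl)sulfanyl on an aromatic carbon. Among the compounds with values here, no pair of measured compounds here differs in just one place, so no measured step can guide the size of this change. The expectation is a modest shift, if any, within or only just beyond the scatter, with the number for compound 4 estimated a little higher than that of compound 2, a step of a 1.3-fold higher number from compound 2 to compound 4 (0.11 log units; within the scatter). Compound 4 is therefore expected to give about 500 nM in this assay, most likely between 150 nM and 1600 nM.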

Compound 4, half-maximal inhibitory concentration: 79.4 nM
Beside the measured number, compound 4's estimate is 6.3-fold (0.80 log units) above it, and the stated range ends above it.
By their numbers in this assay, from the lowest: compound 1; then compound 4; then compound 2; then compound 3.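

At this position on the aromatic ring, ortho to a chloro group and para to a fluoro group, the choice of group clearly matters: swapping ((methoxycarbonyl)methyl)sulfanyl for propargyloxy gives a 4.9-fold lower number from compound 2 to compound 4 (0.69 log units; beyond the scatter) in this assay and lies beyond the usual scatter. The entering group has fewer heavy atoms and fewer hydrogen-bond acceptors, so the lower number does not depend on keeping the larger chain with its carbonyl. No measurement available here explains the step.

The change replaces a sulfur link with an oxygen link and also alters the rest of the chain, so the compounds shown cannot say which part of it matters. A methoxy group, a propoxy chain or a propargylsulfanyl group at this position could help separate the link from the triple bond.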